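The source may report more compounds than this note shows. Statements on the series, on what has been measured and on what is new or still open speak of the compounds shown alone.

Working notes on a series built on one shared core. Compound 3 `COc1ccc(/C=C\C(=O)O)c(OCc2cn(-c3ccccc3)nn2)c1CC=C(C)C` carries a bare phenyl and, in a functional assay on NCI-H322 cells (Homo sapiens) for cytotoxicity, read by MTT assay, with a stated time of 24 h (a higher number here means a weaker inhibitor, a lower number a stronger inhibitor), compound 3 gives 29200 nM. Compound 1 `COc1ccc(/C=C\C(=O)O)c(OCc2cn(-c3ccc(NC(C)=O)cc3)nn2)c1CC=C(C)C` gives 45700 nM, and compound 2 `COc1ccc(/C=C\C(=O)O)c(OCc2cn(-c3ccc(NC(=O)c4ccccc4)cc3)nn2)c1CC=C(C)C` gives 17200 nM. Within the data shown here, compound 3 thus stands second highest of the three numbers; a 1.6-fold lower number from compound 1 to compound 3 (0.19 log units; within the scatter) and a 1.7-fold higher number from compound 2 to compound 3 (0.23 log units; within the scatter) both sit within the scatter, so no order among compounds 1, 2 and 3 is claimed, while a 2.7-fold lower number from compound 1 to compound 2 (0.42 log units; beyond the scatter) is the only step in the set that leaves the scatter and is modest at that.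

Compound 4 `COc1ccc(/C=C\C(=O)O)c(OCc2cn(-c3ccc(C#N)cc3)nn2)c1CC=C(C)C` differs from compound 3 by cyano in place of hydrogen on an aromatic carbon. Among the measured compounds shown here, the steps that bear on this change are those that swap the group borne by the phenyl: a 1.6-fold lower number from compound 1 to compound 3 (0.19 log units; within the scatter) and a 1.7-fold higher number from compound 2 to compound 3 (0.23 log units; within the scatter). Two groups of quite different size on that phenyl gave numbers within the scatter of the bare phenyl, and the whole set spans little more than a modest step. For cyano, a small group with one acceptor, the expectation in this assay is therefore no step beyond the scatter, in either direction. Compound 4 is expected to give about 27000 nM, with a range from 11000 nM to 65000 nM. That estimate means an expected 1.1-fold lower number from compound 3 to compound 4 (0.03 log units; within the scatter).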

Compound 4, half-maximal inhibitory concentration: 18600 nM
Beside the measured number, compound 4's estimate is 1.5-fold (0.16 log units) above it; the measured number falls inside the stated range.
By their numbers in this assay, from the lowest: compounds 2, 4, 3 and 1 (each within the scatter of the next, the first and the last beyond it).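

In this assay, cyano on the phenyl, para to a large group, gives a step within the scatter (a 1.6-fold lower number from compound 3 to compound 4 (0.20 log units; within the scatter)), so a third substituent, and the first without an amide, stays within the scatter of the bare phenyl at this position. Cyano also stays within the scatter of benzamido (a 1.1-fold higher number from compound 2 to compound 4 (0.03 log units; within the scatter)) but not of acetamido (a 2.5-fold lower number from compound 1 to compound 4 (0.39 log units; beyond the scatter)), a modest step that gives the acetamido compound a second step beyond the scatter, although its step to the bare phenyl remains within it, and the set follows no order by group size, since the small cyano and the much larger benzamido fall within the scatter of each other while acetamido, intermediate in size, is the group that stands apart. No measured evidence is at hand to account for these numbers.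

Open, as far as these compounds go, is whether an amine or a carboxylic acid on this phenyl would give a step beyond the scatter from the bare phenyl. Also open, from the compounds shown here alone, is whether a longer chain in place of the phenyl would move the number further than any of these substituents has.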